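A Sulfonamide Variant Against an Aortic Calcium Channel Assay

The source may report more compounds than this note shows. Statements on the series, on what has been measured and on what is new or still open speak of the compounds shown alone.

Of the compounds shown here, two have been measured in a functional assay on aorta for antagonist activity at Voltage-gated L-type calcium channel (Rattus norvegicus); a lower number here means a stronger inhibitor, a higher number a weaker inhibitor. Compound 1 `CC1=C(C(=O)OC(C)C)C(c2cccc(Cl)c2)N(CCCN(C)C(=O)c2ccc(Oc3ccccc3)cc2)C(=O)N1` gives 2100 nM; 3800 nM; 2100 nM (3 entries) in this assay. Compound 2 `CC(C)OC(=O)CN(c1cccc(Cl)c1)S(=O)(=O)c1cccc(NC(=O)CCc2ccccc2)c1` is reported in this assay only as > 30000 nM, which is a limit of the assay and not a number. Of the two values shown, compound 2 sits at the weak end, at the limit of > 30000 nM in this assay, at which 1 of the 2 values shown sits. Compound 3 `CC(C)OC(=O)CN(c1cccc(Cl)c1)S(=O)(=O)c1cccc(NC(=O)CN(C)C(=O)OCc2ccccc2)c1` has not yet been measured in this assay. It differs from compound 2 in one place: (benzyloxycarbonyl)(methyl)amino in place of benzyl on a saturated chain carbon bound to a carbonyl carbon. Within the data shown here, no measured pair shows how this change acts on potency. Compound 2 already stands at the limit of > 30000 nM in this assay, at which 1 of the 2 values shown sits, and for compound 3 no step beyond the scatter is expected. The expected step is a step that the limit leaves unreadable from compound 2 to compound 3. Compound 3 is expected to give 40000 nM in this assay, within a range from 15000 nM to 120000 nM, and most likely to be reported only as a limit.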

Compound 3, half-maximal inhibitory concentration: 15000 nM
Beside the measured number, compound 3's estimate is 2.7-fold (0.43 log units) above it, and the stated range covers the measured number.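

In this assay, among these compounds, compound 3 gives 15000 nM, which puts a readable number on this pair for the first time. The entry for compound 2, > 30000 nM, is a limit and not a number. Placing (benzyloxycarbonyl)(methyl)amino in place of benzyl on a saturated chain carbon bound to a carbonyl carbon comes with an at least 2.0-fold lower number from compound 2 to compound 3 (0.30 log units; that floor lies within the scatter), so this place accepts the entering group without loss of a measurable number, yet the size of any real gain stays unsettled.

The compounds shown leave open which part of the entering group matters, since the methyl on its nitrogen and its benzyloxycarbonyl arrive together. A plain dimethylamino group, a carboxylic acid or a longer chain at the same carbon could begin to separate those parts.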